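A few compounds are considered here, and "the series" means these few. Any claim that something is new, unique, unknown or untested is made for them only; others in the source may bear on it.

Compound 3 `COc1cccc(OC)c1OCCNCCOc1ccccc1OCc1ccccc1[N+](=O)[O-]` carries a 2-nitrophenyl group on the saturated chain carbon bound to an oxygen on an aromatic ring of the shared core. In an assay on CHO cells for displacement of a labelled ligand from Alpha-1A adrenergic receptor (Homo sapiens) (on this read-out lower numbers stand for stronger inhibition and higher numbers for weaker inhibition), compound 3 gives 7.94 nM, the highest of the three numbers measured. Compound 1 `COc1cccc(OC)c1OCCNCCOc1ccccc1OCc1cccc(C)c1`, with 3-methylphenyl at that carbon, gives 0.398 nM, and compound 2 `COc1cccc(OC)c1OCCNCCOc1ccccc1OCc1ccc(C)cc1`, with 4-methylphenyl, gives 2 nM. The steps of a 20-fold higher number from compound 1 to compound 3 (1.30 log units; beyond the scatter) and a 4.0-fold higher number from compound 2 to compound 3 (0.60 log units; beyond the scatter) both run upward toward compound 3, and the step of a 5.0-fold higher number from compound 1 to compound 2 (0.70 log units; beyond the scatter) separates the two methylphenyl compounds from each other.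

Compound 4 `COc1cccc(COc2ccccc2OCCNCCOc2c(OC)cccc2OC)c1` differs from compound 3 by 3-methoxyphenyl in place of 2-nitrophenyl on a saturated chain carbon bound to an oxygen on an aromatic ring. Both measured steps toward compound 3 show that replacing a methylphenyl group with the 2-nitrophenyl group raised the number, the large step from compound 1 being the more relevant because a 20-fold higher number from compound 1 to compound 3 (1.30 log units; beyond the scatter) involves a 3-substituted phenyl like the 3-methoxyphenyl that enters. The reverse direction is therefore expected to lower the number, though the methoxy group is not the methyl of compound 1 and no step for a methoxy group is shown, so the expected step of a 7.9-fold lower number from compound 3 to compound 4 (0.90 log units; beyond the scatter) is kept somewhat smaller than that full reversal. Compound 4 is estimated to give 1 nM in this assay, within a range from 0.3 nM to 4 nM.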

Compound 4, inhibition constant: 2 nM
Beside the measured number, compound 4's estimate is 2.0-fold (0.30 log units) below it; the measured number falls inside the stated range.
By their numbers in this assay, from the lowest: compound 1; then compounds 2 and 4 (each within the scatter of the next); then compound 3.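

The step of a 4.0-fold lower number from compound 3 to compound 4 (0.60 log units; beyond the scatter) in this assay shows that the higher number of the 2-nitrophenyl compound is not shared by every other substituted phenyl group on this saturated chain carbon. The methoxy group also gives the first direct comparison within a 3-substituted phenyl group, and the step of a 5.0-fold higher number from compound 1 to compound 4 (0.70 log units; beyond the scatter) shows that methoxy in place of methyl on an aromatic carbon does not preserve the lowest number, which stays with compound 1. The step of no change at the digits printed from compound 2 to compound 4 (within the scatter) adds that 3-methoxyphenyl and 4-methylphenyl cannot be told apart in this read-out, so the 3-substituted pattern does not hold for compound 4 alone, and no evidence is available to explain any of these steps.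

The compounds shown leave open whether the higher number of compound 3 goes with the nitro group or with its place on the ring, a question that 3-nitrophenyl and 2-methylphenyl groups at this carbon would separate. Also open is where an unsubstituted phenyl, a 3-chlorophenyl or a 4-methoxyphenyl group would fall among these four compounds.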